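The source may report more compounds than this note shows. Statements on the series, on what has been measured and on what is new or still open speak of the compounds shown alone.

Measured so far in a functional assay on the whole organism (strain BALB/c) for inhibition, with Mus musculus as the target, read by paw edema, with a stated time of 4 h, at a dose of 50 mg/kg by the oral route; a lower number here means less inhibition, a higher number more inhibition at the dose given (going by the name of the read-out):
Compound 1 `COc1ccc(Nc2nnc(-c3cc(-c4ccc(F)cc4F)ccc3O)o2)cc1` gives 35.3%.
Compound 2 `C=CCNc1nnc(-c2cc(-c3ccc(F)cc3F)ccc2O)s1` gives 57.2%.
Compound 3 `CCn1c(-c2cc(-c3ccc(F)cc3F)ccc2O)n[nH]c1=S` gives 46.2%.

Among these three, compound 1 stands lowest. Its nearest neighbour is compound 3, whose number lies higher by a gap beyond the usual scatter, and compound 2 lies higher still, again beyond the scatter. Compound 4 `Oc1ccc(-c2ccc(F)cc2F)cc1-c1nnc(NC2CCCCC2)o1` has not yet been measured. It differs from compound 1 in one place: cyclohexyl in place of 4-methoxyphenyl on a nitrogen on an aromatic ring. The 4-methoxyphenyl group, an aromatic ring with one hydrogen-bond acceptor, leaves; the cyclohexyl group, a non-aromatic ring with none, enters; everything else stays. Among the compounds with values here, no measured pair shows this change, so the expectation rests only on where compound 1 stands. For compound 4 a small rise is expected, a number 8.7 percentage points higher from compound 1 to compound 4 (within the scatter), which may still fall within the scatter. The estimate for compound 4 in this assay is 44%, ranging from 30% to 58%.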

Compound 4, a percentage reported as inhibition, in the whole organism at one dose (the size of the read-out at that dose, not a potency): 23.8%
For compound 4 the middle estimate is 20.2 percentage points above the measured one; measured number below the stated range.
By their numbers in this assay, from the lowest: compound 4; then compound 1; then compound 3; then compound 2.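

In this assay, the group on this nitrogen on an aromatic ring does affect the read-out: cyclohexyl in place of 4-methoxyphenyl gives a number 11.5 percentage points lower from compound 1 to compound 4 (beyond the scatter). Within the data shown here, this is the first comparison in which only one place changes, and here the aromatic group gives the higher number, though this single pair sets no general rule. Nothing available explains the step.

The compounds shown leave open whether the aromatic ring or its methoxy group matters more. A plain phenyl group on this nitrogen would separate the two.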